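The compounds below may be only part of what the source reports. "The series", "measured", "known", "first", "only" and "open" are said of these compounds alone.

Measured so far in an ADME assay on CHO-K1 cells (Cricetulus griseus) for cytotoxicity; a lower number here means a stronger inhibitor, a higher number a weaker inhibitor:

Compound 1 `C=C1CCC[C@H]2[C@](C)(Cc3cc(OC(C)=O)ccc3O)[C@@H](C)CC[C@]12C` gives > 27300 nM, which is a limit of the assay and not a number. Compound 2 `CC(=O)Oc1ccc(OC(C)=O)c(C[C@]2(C)[C@@H](C)CC[C@]3(C)C(C)=CCC[C@@H]23)c1` gives > 24400 nM, again a limit. Compound 3 `COc1ccc(O)c(C[C@]2(C)[C@@H](C)CC[C@]3(C)C(C)=CCC[C@@H]23)c1` gives > 29600 nM, also a limit.

Going by the values given here, compound 1 therefore stands at the limit of > 27300 nM in this assay, at which 1 of the 3 values shown sits, and none of the three values shown is a number, so no step between measured compounds can be counted here and no order among them can be stated.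

Compound 4 `C=C1CCC[C@H]2[C@](C)(Cc3cc(OC)ccc3O)[C@@H](C)CC[C@]12C` differs from compound 1 by methyl in place of acetyl on an oxygen on an aromatic ring. Since every measured value sits at a limit, the step from compound 1 to compound 4 in this assay is expected to be none beyond the scatter, and the estimated step that the limit leaves unreadable from compound 1 to compound 4 expresses that. Compound 4 is expected to give about 30000 nM, between 15000 nM and 60000 nM, most likely reported as a limit.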

Compound 4, half-maximal inhibitory concentration: > 29600 nM
Compound 4: only a limit was reported (the forecaster's own chance of this, stated with the estimate: 85%); the middle value is on the limit's open side.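

Going by these compounds alone, compound 1 and compound 4 are both reported only as limits, and no step between them can be read. The compounds shown leave open whether methyl in place of acetyl on that oxygen changes the read-out in this assay at all.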